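This account rests on a few compounds, and the source may have more. Where it says the series, first, only, none or still open, it means among the compounds named here.

Compound 1 has the structure `CC(C)N(Cc1cccc(OCCCCCC(=O)O)c1)C(=O)c1ccc(-c2ccncc2)cc1`; in an ADME assay on BJ cells (Homo sapiens) for cytotoxicity, read by CellTiter-Glo and resazurin assay, with a stated time of 72 h (a higher number here means that more compound is needed for the effect, a lower number that less compound is needed), compound 1 gives > 26000 nM, which is a limit of the assay and not a number.
Compound 2 has the structure `CC(C)N(Cc1cccc(OCCCCCC(=O)O)c1)C(=O)c1ccc(-c2cccc(C(F)(F)F)c2)cc1`; in this assay compound 2 gives > 26000 nM, again a limit.
Compound 3 has the structure `CC(C)N(Cc1cccc(OCCCCCC(=O)O)c1)C(=O)c1ccc(-c2ccc(Cl)c(Cl)c2)cc1`; in this assay compound 3 gives > 26000 nM, also a limit.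

Compound 3 therefore stands at the same limit as the other two measured compounds: no number separates it from compound 1 or compound 2, and none of them can be called more or less toxic to the cells than another. The unmeasured compound 4 has the structure `CC(C)N(Cc1cccc(OCCCCCC(=O)O)c1)C(=O)c1ccc(-c2cccc(Cl)c2)cc1` and differs from compound 3 by hydrogen in place of chloro on an aromatic carbon. The measured steps that touch compound 3 are a step that the two limits leave unreadable from compound 2 to compound 3 and a step that the two limits leave unreadable from compound 1 to compound 3; both are unreadable, because of the limit of > 26000 nM in this assay, at which 3 of the 3 values shown sit. Changing the group on the outer ring has so far never produced a readable value at all, so there is no ground to expect a step beyond the scatter in this assay in either direction for the smaller change from compound 3 to compound 4. The expected step is a step that the limit leaves unreadable from compound 3 to compound 4, essentially none. Compound 4 is therefore estimated at 30000 nM, within a range from 15000 nM to 80000 nM, most probably reported once more as a limit.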

Compound 4, half-maximal effective concentration: > 21900 nM
Compound 4 was reported as a limit; the forecaster's own chance of this, stated with the estimate: 85%; the middle value lies beyond the limit too.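

The steps from compound 3, compound 2 and compound 1 to compound 4 cannot be read, because all four compounds stand at limits of the assay and not at numbers: the limit of > 21900 nM in this assay, at which 1 of the 4 values shown sits, and (the limit of > 26000 nM in this assay, at which 3 of the 4 values shown sit). The compounds shown leave open at what concentration, if any, each one harms the cells, and whether changing the outer ring group matters.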